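From ethyl to cyano: one small swap, one open question

A few compounds are considered here, and "the series" means these few. Any claim that something is new, unique, unknown or untested is made for them only; others in the source may bear on it.

Among the compounds with values here, in a functional assay on U-87MG ATCC cells for inhibition, with U-87 MG (Homo sapiens) as the target, read by MTT assay, with a stated time of 48 h (a lower number here means a stronger inhibitor, a higher number a weaker inhibitor), compound 1 `CCc1ccc(-c2nc3ccccn3c2Sc2ccccc2)cc1` gives 61700 nM as the only exact number so far. Compound 2 `c1ccc(Sc2c(-c3ccccc3)nc3ccc(-c4ccccc4)cn23)cc1` shows > 100000 nM in this assay as a limit of the assay and not a number. Compound 1 therefore has no exact value to be ranked against.

The next compound to be tested is compound 3 `N#Cc1ccc(-c2nc3ccccn3c2Sc2ccccc2)cc1` and it has cyano in place of ethyl on an aromatic carbon, para to a large group. Read as a whole, this is the change from 4-ethylphenyl to 4-cyanophenyl, and the count of what leaves and enters is cyano in place of ethyl on an aromatic carbon for anyone tallying the atoms.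

Within the data shown here, no measured pair here shows what such a swap does, so the only anchor is compound 1 at 61700 nM in this assay for now. The expected step is a 1.0-fold lower number from compound 1 to compound 3 (0.01 log units; within the scatter) and it should stay within the usual scatter, with neither direction favoured. For compound 3 the estimated value is 60000 nM with an expected range from 25000 nM to 100000 nM in this test.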

Compound 3, half-maximal inhibitory concentration: 65500 nM
Beside the measured number, compound 3's estimate is 1.1-fold (0.04 log units) below it; measured number inside the range.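

Putting cyano in place of ethyl here gives a 1.1-fold higher number from compound 1 to compound 3 (0.03 log units; within the scatter), so in this assay the two compounds cannot be told apart. Within the data shown here, this is the first measured pair that differs in one place only, and it shows that, on an aromatic carbon para to a large group, 4-ethylphenyl and 4-cyanophenyl read alike in this test, even though cyano brings a triple bond and a hydrogen-bond acceptor that ethyl does not have. Compound 2 is still a limit of the assay and not a number, so no step to it can be read and the new pair is the only comparison available: the limit of > 100000 nM in this assay, at which 1 of the 3 values shown sits.

What one flat pair leaves open is whether this position responds to any swap at all, since an amine, a carboxylic acid or a longer chain such as butyl on the same carbon could read quite differently from ethyl and cyano. On these data alone, it also remains open whether cyano in place of ethyl would read alike on a compound whose number lies well away from those of compound 1 and compound 3.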